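Lengthening the amine chain on a 3-alkoxyflavone core

The source may hold more compounds than are shown below. What is called first, only, known or untested is meant among the compounds shown, and "the series" means these compounds.

The measured compounds in a functional assay on DU-145 cells (Homo sapiens) for antiproliferative activity, read by WST assay, with a stated time of 3 days (on this read-out higher numbers stand for weaker inhibition and lower numbers for stronger inhibition), are these:
- compound 1, `CCC(C)Oc1c(-c2cc(OC)c(OC)c(OC)c2)oc2ccccc2c1=O`, a limit of > 50000 nM
- compound 2, `CCCC(C)Oc1c(-c2cc(OC)c(OC)c(OC)c2)oc2ccccc2c1=O`, a limit of > 50000 nM
- compound 3, `CCN(CC)CCCOc1c(-c2cc(OC)c(OC)c(OC)c2)oc2ccccc2c1=O`, a limit of > 50000 nM

All three share the same core and differ only in the group on the ether oxygen. Compound 3 stands at the assay limit, and so does every other value shown, as noted in the limit of > 50000 nM in this assay, at which 3 of the 3 values shown sit. For that reason the step that the two limits leave unreadable from compound 1 to compound 2 is not readable, nor is a step that the two limits leave unreadable from compound 1 to compound 3, nor a step that the two limits leave unreadable from compound 2 to compound 3.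

Compound 4, `CCCCCN(CCCCC)CCCOc1c(-c2cc(OC)c(OC)c(OC)c2)oc2ccccc2c1=O`, has not yet been measured in this assay. It differs from compound 3 by dipentylamino in place of diethylamino on a saturated chain carbon, three bonds along the chain from an oxygen on an aromatic ring. For the measured compounds named here, no measured step bears directly on this change: the two steps that alter the ether substituent, from compound 1 to compound 3 and from compound 2 to compound 3, are both unreadable, and none of them exchanges one dialkylamino group for another. What can be said is that three different ether groups, including the diethylamino-bearing one of compound 3, all leave the value at the limit.

On this basis compound 4 is expected to remain at the limit, with an estimated step that the limit leaves unreadable from compound 3 to compound 4 from compound 3. The estimate for compound 4 is therefore 60000 nM, in the range 15000 nM to 250000 nM.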

Compound 4, half-maximal inhibitory concentration: 12300 nM
Beside the measured number, compound 4's estimate is 4.9-fold (0.69 log units) above it; the measured number lies below the stated range.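

In this assay, exchanging diethylamino for dipentylamino on a saturated chain carbon, three bonds along the chain from an oxygen on an aromatic ring, gives an at least 4.0-fold lower number from compound 3 to compound 4 (0.60 log units; beyond the scatter), the only step shown whose direction can be read. The earlier steps among the ether groups cannot be read, so this result is the first sign that the alkyl groups on the amine can change the read-out at all, and compound 4 is the only compound shown with a value that is a number. The true size of the step stays open on one side, since compound 3 carries only a limit: the limit of > 50000 nM in this assay, at which 3 of the 4 values shown sit.

The compounds shown leave open whether dipropylamino or dibutylamino would already give a number, and whether alkyl chains longer than pentyl on the amine would lower it further. They also leave open how a ring amine such as piperidine would compare with dipentylamino, and what a shorter or longer chain between the amine and the ether oxygen would do.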